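Swapping a methyl for a 2-fluorophenyl on the ring amine

The source may hold more compounds than are shown below. What is called first, only, known or untested is meant among the compounds shown, and "the series" means these compounds.

Among the measured compounds shown here, compound 1 `CN1CCN(c2nc(Nc3ccc(C#N)c(C(F)(F)F)c3)nc(Oc3ccnc4ccccc34)n2)CC1` is the only compound of this set with a measured number. In a functional assay on DU-145 cells (Homo sapiens) for cytotoxicity, read by sulforhodamine B assay, with a stated time of 48 h (on this read-out higher numbers stand for weaker inhibition of growth and lower numbers for stronger inhibition of growth), compound 1 gives 51200 nM. Compound 2 `N#Cc1ccc(Nc2nc(Oc3ccnc4ccccc34)nc(N3CCC(Cc4ccccc4)CC3)n2)cc1C(F)(F)F`, which carries a different ring amine on the shared core, is reported in this assay only as a limit of the assay, > 100000 nM. Compound 2 therefore illustrates (the limit of > 100000 nM in this assay, at which 1 of the 2 values shown sits), so no comparison between a measured number of compound 1 and a measured number of compound 2 can be drawn.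

Compound 3 `N#Cc1ccc(Nc2nc(Oc3ccnc4ccccc34)nc(N3CCN(c4ccccc4F)CC3)n2)cc1C(F)(F)F` keeps the core of compound 1 and changes one place: 2-fluorophenyl in place of methyl on an amine nitrogen in a ring. For the measured compounds named here, no pair of measured compounds differs by this change alone, so the size of the step is open. With only compound 1 as a measured anchor and compound 2 sitting at a limit, a modest move toward weaker inhibition of growth is expected, though a result within the usual scatter of compound 1 is also plausible. Compound 3 is therefore estimated at 70000 nM, in the range 20000 nM to 150000 nM, which is an expected step of a 1.4-fold higher number from compound 1 to compound 3 (0.14 log units; within the scatter).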

Compound 3, concentration for 50% growth inhibition: > 100000 nM
Compound 3: a limit, no number (the forecaster's own chance of this, stated with the estimate: 40%); at least 1.4-fold (0.15 log units) between middle value and limit.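

In this assay compound 3 is reported only as a limit of the assay, > 100000 nM, and not as an exact number. Placing 2-fluorophenyl where methyl stood on the ring nitrogen therefore gives an at least 1.9-fold higher number from compound 1 to compound 3 (0.29 log units; that floor lies within the scatter), so only a floor is known for this step, and the true step may or may not exceed the usual scatter. What this adds is that 2-fluorophenyl at this place brought no measurable gain in growth inhibition over methyl, and that the read-out has little room left to separate further compounds of this kind: the limit of > 100000 nM in this assay, at which 2 of the 3 values shown sit.

Going by these compounds, it remains open whether any group on this ring nitrogen could give stronger inhibition of growth than methyl, which a hydrogen, an ethyl group or a hydroxyethyl chain at the same place would help to test. Also open, on these data alone, are the true distance between compound 1 and compound 3 and whether the fluorine matters at all, which a plain phenyl at this place would help to show.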